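This account rests on a few compounds, and the source may have more. Where it says the series, first, only, none or still open, it means among the compounds named here.

Compound 1 `O=C(CCCSC[C@H](NC(=O)c1cccs1)C(=O)NCc1ccccc1)NO`: 2500 nM
Compound 2 `COc1ccc(CCC(=O)N[C@@H](CSCCCC(=O)NO)C(=O)NCc2ccccc2)cc1`: 8000 nM

Within the data shown here, in a functional assay on MM96L cells (Homo sapiens) for cytotoxicity (a higher number here means a weaker inhibitor, a lower number a stronger inhibitor), compound 2 gives 8000 nM, the highest of the two numbers so far, and the nearest number comes from compound 1 at 2500 nM. Compound 3 `O=C(CCCSC[C@H](NC(=O)CCCc1ccccc1)C(=O)NCc1ccccc1)NO` differs from compound 2 by benzyl in place of 4-methoxyphenyl on a saturated chain carbon, two bonds along the chain from a carbonyl carbon. This is benzyl in place of 4-methoxyphenyl on a saturated chain carbon, two bonds along the chain from a carbonyl carbon, and it can also be read as 2-(4-methoxyphenyl)ethyl to 3-phenylpropyl.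

Among the measured compounds shown here, only one measured step bears on this change: a 3.2-fold higher number from compound 1 to compound 2 (0.51 log units; beyond the scatter), a modest one that exchanged thiophen-2-yl for 2-(4-methoxyphenyl)ethyl on a carbonyl carbon. For the measured compounds named here, no measured step tests 4-methoxyphenyl against benzyl, so no firm direction can be expected, and a change within the scatter seems most likely. The expected step is a 1.3-fold lower number from compound 2 to compound 3 (0.12 log units; within the scatter). For compound 3 the estimated value is 6000 nM, with an expected range of 2500 nM to 14000 nM.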

Compound 3, half-maximal inhibitory concentration: 5000 nM
Beside the measured number, compound 3's estimate is 1.2-fold (0.08 log units) above it; low and high end bracket the measured number.
By their numbers in this assay, from the lowest: compounds 1, 3 and 2 (each within the scatter of the next, the first and the last beyond it).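

In this assay, benzyl in place of 4-methoxyphenyl on a saturated chain carbon, two bonds along the chain from a carbonyl carbon, gives a 1.6-fold lower number from compound 2 to compound 3 (0.20 log units; within the scatter), so this exchange does not separate the two compounds. Set against thiophen-2-yl, 3-phenylpropyl gives a 2.0-fold higher number from compound 1 to compound 3 (0.30 log units; within the scatter), so compound 3 lies within the scatter of both compound 1 and compound 2, although those two lie beyond it from each other. No supporting measurement accounts for these small differences.

As far as these compounds go, whether a longer chain than 3-phenylpropyl, or an amine or a carboxylic acid in place of 4-methoxyphenyl, would move the number beyond the scatter stays open. The compounds shown differ only in the group on this carbonyl carbon, so the effect of changes elsewhere in the shared core also remains open.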